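A few compounds are considered here, and "the series" means these few. Any claim that something is new, unique, unknown or untested is made for them only; others in the source may bear on it.

Series notes. Three analogues sharing one core have been measured in an assay on CHO cells for displacement of a labelled ligand from adenosine receptor A1 (Homo sapiens), read by scintillation counting, with a stated time of 90 min, in the presence of a further agent that is not named here; on this read-out higher numbers stand for weaker inhibition and lower numbers for stronger inhibition. Compound 1 `CCCn1c(=O)[nH]c2nc(-c3ccc(S(=O)(=O)N4CCN(c5ccccc5Br)CC4)cc3)[nH]c2c1=O` carries 2-bromophenyl on the amine nitrogen in the ring; for compound 1 this assay gives only a limit, > 1000 nM. Compound 2 `CCCn1c(=O)[nH]c2nc(-c3ccc(S(=O)(=O)N4CCN(c5ccc(Br)cc5)CC4)cc3)[nH]c2c1=O` carries 4-bromophenyl in that position; for compound 2 this assay likewise reports only a limit, > 1000 nM. Compound 3 `CCCn1c(=O)[nH]c2nc(-c3ccc(S(=O)(=O)N4CCN(c5ccccc5)CC4)cc3)[nH]c2c1=O` carries unsubstituted phenyl; in this assay compound 3 gives 364 nM. For the measured compounds named here, compound 2 therefore stands at the limit of > 1000 nM in this assay, at which 2 of the 3 values shown sit, beside compound 1, with compound 3 holding the only numerical value in the set. The step that the two limits leave unreadable from compound 1 to compound 2 cannot be read. The steps of an at least 2.7-fold lower number from compound 1 to compound 3 (0.43 log units; beyond the scatter) and an at least 2.7-fold lower number from compound 2 to compound 3 (0.43 log units; beyond the scatter) both show that hydrogen in place of bromo brings the number down.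

Compound 4 `CCCn1c(=O)[nH]c2nc(-c3ccc(S(=O)(=O)N4CCN(c5ccc(C)cc5)CC4)cc3)[nH]c2c1=O` differs from compound 2 by methyl in place of bromo on an aromatic carbon. Going by the values given here, the only measured step bearing on this change is an at least 2.7-fold lower number from compound 2 to compound 3 (0.43 log units; beyond the scatter), where bromo leaves and hydrogen enters; no measured pair shows methyl entering. From the compounds shown here alone, since bromo leaving gave an at least modest lowering in an at least 2.7-fold lower number from compound 2 to compound 3 (0.43 log units; beyond the scatter), a downward move is expected here too, though whether methyl matches hydrogen in this respect is unknown from the data. The expected step in this assay is estimated as an at least 1.4-fold lower number from compound 2 to compound 4 (0.15 log units; that floor lies within the scatter). Compound 4 is expected to give about 700 nM in this assay, within 300 nM to 2000 nM, with a real chance that only a limit is reported.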

Compound 4, inhibition constant: > 1000 nM
Compound 4: no number, only a limit (the forecaster's own chance of this, stated with the estimate: 40%); middle value at least 1.4-fold (0.15 log units) away from the limit.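

With methyl in place of hydrogen on the aromatic carbon, para to a large group, this assay shows an at least 2.7-fold higher number from compound 3 to compound 4 (0.43 log units; beyond the scatter), so the upward move from unsubstituted phenyl is no longer tied to bromo alone. Across the compounds shown, every substituted phenyl gives a higher number than the unsubstituted phenyl of compound 3, and none goes against this, although for compounds 1, 2 and 4 that comparison rests on limits. Compound 4 gives only a limit and joins compounds 1 and 2 there: the limit of > 1000 nM in this assay, at which 3 of the 4 values shown sit.

From the compounds shown here alone, the steps among compounds 1, 2 and 4 cannot be read, so bromo and methyl at this place, and 2-bromophenyl against 4-bromophenyl, remain unordered, and how far any of the three lies past the limit is unknown. Going by these compounds, whether fluoro, methoxy or an amine on this phenyl ring would also raise the number relative to compound 3 remains open, as does whether the same change behaves alike on a core other than the shared one.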